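A few compounds are considered here, and "the series" means these few. Any claim that something is new, unique, unknown or untested is made for them only; others in the source may bear on it.

Compound 3 `CC(C)(C)c1cc(C(C)(C)C)c2oc(=O)c(/C=N/c3ccc(S(N)(=O)=O)cc3)c(Cl)c2c1` carries two tert-butyl groups on its core and an unsubstituted sulfonamide. Within the data shown here, in an ADME assay on cells (Macrophage, Homo sapiens) for cytotoxicity, read by microscopy and CCK-8 assay, with a stated time of 48 h (on this read-out higher numbers stand for lower toxicity in this test and lower numbers for higher toxicity in this test), compound 3 gives 580 nM, the second highest of the three numbers so far; compound 1 `N=C(N)NS(=O)(=O)c1ccc(/N=C/c2c(Cl)c3ccccc3oc2=O)cc1` gives 620 nM and compound 2 `Cc1cc(NS(=O)(=O)c2ccc(/N=C/c3c(Cl)c4ccccc4oc3=O)cc2)no1` gives 420 nM, both within the usual scatter of compound 3.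

Compound 4 `Cc1ccnc(NS(=O)(=O)c2ccc(/N=C/c3c(Cl)c4cc(C(C)(C)C)cc(C(C)(C)C)c4oc3=O)cc2)n1` differs from compound 3 in one place: 4-methylpyrimidin-2-yl in place of hydrogen on a sulfonamide nitrogen. Among the measured compounds shown here, no measured pair changes a bare sulfonamide nitrogen into a substituted one. The closest comparison is the exchange of one sulfonamide-nitrogen substituent for another, a 1.5-fold lower number from compound 1 to compound 2 (0.17 log units; within the scatter), which stayed within the scatter. For the measured compounds named here, since that exchange on the same nitrogen left the read-out essentially unmoved, and the three numbers so far are all of a similar size, no step beyond the scatter is expected for compound 4 in this assay in either direction.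

The step from compound 3 to compound 4 is therefore expected to be a 1.1-fold lower number from compound 3 to compound 4 (0.05 log units; within the scatter). Compound 4 is estimated at 520 nM, with a range from 250 nM to 1100 nM.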

Compound 4, minimum cytotoxic concentration: 360 nM
Beside the measured number, compound 4's estimate is 1.4-fold (0.16 log units) above it; the measured number falls inside the stated range.
By their numbers in this assay, from the lowest: compounds 4, 2, 3 and 1 (each within the scatter of the next).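

Among these compounds, with compound 4, the bare sulfonamide nitrogen carries a substituent for the first time, and in this assay the change is a 1.6-fold lower number from compound 3 to compound 4 (0.21 log units; within the scatter). This shows that 4-methylpyrimidin-2-yl can take the place of hydrogen on this nitrogen, on a core carrying two tert-butyl groups, without a step beyond the scatter, whereas the earlier pair only exchanged one substituent for another. No supporting evidence bears on this result.

From the compounds shown here alone, it remains open whether a carboxylic acid or an aliphatic amine on the same nitrogen would also stay within the scatter. What the two tert-butyl groups contribute on their own is also unresolved, as no pair shown differs only there.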